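The source may report more compounds than this note shows. Statements on the series, on what has been measured and on what is new or still open speak of the compounds shown alone.

Compound 1 `CCOC(=O)C(C)Nc1cccc2c(S(=O)(=O)Nc3onc(C)c3C)cccc12`: 400 nM
Compound 2 `Cc1noc(NS(=O)(=O)c2cccc3c(N4CCCC4=O)cccc23)c1C`: 130 nM
Compound 3 `Cc1noc(NS(=O)(=O)c2cccc3c(N/C(S)=N/c4ccccc4)cccc23)c1C`: 150 nM

In an assay on VSM-A10 cells for antagonist activity at Endothelin-1 receptor (Rattus norvegicus) (a higher number here means a weaker inhibitor, a lower number a stronger inhibitor), compound 3 gives 150 nM, the second highest of the three numbers: it lies closest to compound 2, with a 1.2-fold higher number from compound 2 to compound 3 (0.06 log units; within the scatter), and furthest from compound 1, with a 2.7-fold lower number from compound 1 to compound 3 (0.43 log units; beyond the scatter). Compound 4 `Cc1noc(NS(=O)(=O)c2cccc3c(Cl)cccc23)c1C` has not yet been measured. It differs from compound 3 at the same place that was varied among the measured compounds: one chlorine atom in place of a group of 10 heavy atoms (7 carbon, 2 nitrogen, 1 sulfur; one six-membered aromatic ring of carbon only), on an aromatic carbon. Among the measured compounds shown here, the steps that bear on this position are a 2.7-fold lower number from compound 1 to compound 3 (0.43 log units; beyond the scatter), a 1.2-fold higher number from compound 2 to compound 3 (0.06 log units; within the scatter) and a 3.1-fold lower number from compound 1 to compound 2 (0.49 log units; beyond the scatter), so exchanging the group there has moved the numbers only modestly so far. None of the three compounds carries a single chlorine at this place, so the expected range for compound 4 is wide and the expected step from the change is small: a 1.7-fold higher number from compound 3 to compound 4 (0.22 log units; within the scatter). Compound 4 is estimated at 250 nM, between 60 nM and 1000 nM.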

Compound 4, half-maximal inhibitory concentration: 24000 nM
Beside the measured number, compound 4's estimate is 96-fold (1.98 log units) below it; the whole stated range lies below it.
By their numbers in this assay, from the lowest: compounds 2 and 3 (each within the scatter of the next); then compound 1; then compound 4.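

In this assay, exchanging the three larger groups on this aromatic carbon moved the numbers only modestly, but chloro marks a far larger change: a 160-fold higher number from compound 3 to compound 4 (2.20 log units; beyond the scatter), a 180-fold higher number from compound 2 to compound 4 (2.27 log units; beyond the scatter) and a 60-fold higher number from compound 1 to compound 4 (1.78 log units; beyond the scatter). The position therefore accepts quite different groups attached through nitrogen, while a lone chlorine there gives a much weaker inhibitor. Nothing shown explains this drop. Going by these compounds, it remains open whether the loss comes from the chlorine itself or from the missing nitrogen link; a plain amine or a methyl group on this carbon would distinguish these.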